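Adding a Third Methoxy Group to Compound 2

This account rests on a few compounds, and the source may have more. Where it says the series, first, only, none or still open, it means among the compounds named here.

Three compounds share a chalcone-like arrangement joined to a pyrazole core and were tested in a functional assay on PC-3 cells (Homo sapiens) for cytotoxicity, read by sulforhodamine B assay, with a stated time of 48 h, tested at 0.01 uM; a lower number here means a stronger effect, a higher number a weaker effect of the compound at the concentration tested. Compound 3 `COc1ccc(-c2cc(/C=C/C(=O)c3ccc(N)cc3)[nH]n2)cc1OC` gives 95%. Compound 1 `COc1cc(-c2cc(/C=C/C(=O)c3ccc(N)cc3)[nH]n2)cc(OC)c1OC` gives 97%. Compound 2 `COc1ccc(C(=O)/C=C/c2cc(-c3cc(OC)c(OC)c(OC)c3)n[nH]2)cc1OC` gives 96%. At this low concentration all three read close to full activity, meaning little loss of cell growth.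

From compound 3 to compound 1 the change is methoxy in place of hydrogen on an aromatic carbon, and the result is a number 2 percentage points higher from compound 3 to compound 1 (within the scatter). From compound 1 to compound 2 the carbonyl partner is exchanged, and the result is a number 1 percentage points lower from compound 1 to compound 2 (within the scatter). The difference between the cores of compound 2 and compound 3 is not broken down here; their values sit within the scatter of each other.

The unmeasured compound 4 `COc1cc(C(=O)/C=C/c2cc(-c3cc(OC)c(OC)c(OC)c3)n[nH]2)cc(OC)c1OC` arises from compound 2 by methoxy in place of hydrogen on an aromatic carbon. This is the same change that was made from compound 3 to compound 1, at a place described in the same words. The step expected from compound 2 to compound 4, no change at the digits printed from compound 2 to compound 4 (within the scatter), rests on the step seen for compound 1 of a number 2 percentage points higher from compound 3 to compound 1 (within the scatter), which stayed within the scatter. For compound 4 in this assay the estimate is 96%, with a likely range from 88% to 102%.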

Compound 4, a percentage reported as activity, at one concentration (the size of the read-out at that concentration, not a potency): 95%
Compound 4: the middle estimate sits 1 percentage points above what was measured; the range from low to high includes it.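

In this assay, methoxy in place of hydrogen on an aromatic carbon gives a number 1 percentage points lower from compound 2 to compound 4 (within the scatter), so on this second core the read-out again stays where it was. Set beside the earlier case, the two cores cannot be told apart: the same change on two cores in this assay, a number 2 percentage points higher (within the scatter) from compound 3 to compound 1 and a number 1 percentage points lower (within the scatter) from compound 2 to compound 4, 3 percentage points apart, within the scatter of two such steps This shows that, at this single low concentration, the change carried over from one core to the other without a visible effect on either; it does not show that the methoxy group is without effect in general, for all four compounds read close to full activity here, and a flat result under such conditions says little about how the change would behave at a concentration where the compounds clearly reduce cell growth.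

The compounds shown leave open whether a different group in the same place, such as a hydroxyl, a fluorine atom, an amine or a longer chain like ethoxy, would move the read-out on either core. They also leave open how the two steps would compare at higher concentrations, where a real difference between the cores could either appear or stay absent.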